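This account rests on a few compounds, and the source may have more. Where it says the series, first, only, none or still open, it means among the compounds named here.

Measured in a functional assay on MCF7 cells (Homo sapiens) for inhibition, read by sulforhodamine B assay, with a stated time of 48 h; a higher number here means a weaker inhibitor of growth, a lower number a stronger inhibitor of growth:
- compound 1 `COc1cc(-c2cc(/C=C/C(=O)c3ccc(Cl)c(Cl)c3)[nH]n2)cc(OC)c1OC`: > 100000 nM
- compound 2 `COc1ccc(C(=O)/C=C/c2cc(-c3cc(OC)c(OC)c(OC)c3)n[nH]2)cc1OC`: 1950 nM
- compound 3 `COc1ccc(C(=O)/C=C/c2cc(-c3cc(OC)c(OC)c(OC)c3)n[nH]2)cc1`: 2960 nM

Compound 1 gets only a limit from the assay, > 100000 nM, and no number. This is the limit of > 100000 nM in this assay, at which 1 of the 3 values shown sits.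

Compound 4 `COc1cc(-c2cc(/C=C/C(=O)c3ccc(F)c(F)c3)[nH]n2)cc(OC)c1OC` differs from compound 1 in one place: 3,4-difluorophenyl in place of 3,4-dichlorophenyl on a carbonyl carbon. Two measured steps change that same place. In an at least 51-fold lower number from compound 1 to compound 2 (1.70 log units; beyond the scatter), 3,4-dimethoxyphenyl enters, and in an at least 33-fold lower number from compound 1 to compound 3 (1.52 log units; beyond the scatter), 4-methoxyphenyl enters. Both steps are large and beyond the scatter, whereas a 1.5-fold higher number from compound 2 to compound 3 (0.18 log units; within the scatter) stays within it. Among the compounds with values here, no measured compound carries 3,4-difluorophenyl, so these steps suggest the direction better than the size. A lower number is therefore expected in this assay, resting on the reach of an at least 33-fold lower number from compound 1 to compound 3 (1.52 log units; beyond the scatter), but the drop is expected to be smaller than in those steps, and another limit reading remains possible. The expected change is an at least 3.3-fold lower number from compound 1 to compound 4 (0.52 log units; beyond the scatter). For compound 4 the estimated value is 30000 nM, with an expected range from 4000 nM to 100000 nM.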

Compound 4, concentration for total growth inhibition: 12300 nM
Compound 4: the middle estimate sits 2.4-fold (0.39 log units) above what was measured, and the stated range covers the measured number.
By their numbers in this assay, from the lowest: compounds 2 and 3 (each within the scatter of the next); then compound 4. At a limit, above all of these: compound 1.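

Halogen on this ring does not by itself leave a compound at the limit: in this assay, 3,4-difluorophenyl in place of 3,4-dichlorophenyl on a carbonyl carbon gives an at least 8.1-fold lower number from compound 1 to compound 4 (0.91 log units; beyond the scatter). The methoxy-bearing groups still hold the lower numbers, with a 4.2-fold higher number from compound 3 to compound 4 (0.62 log units; beyond the scatter) and a 6.3-fold higher number from compound 2 to compound 4 (0.80 log units; beyond the scatter), so 3,4-difluorophenyl falls between them and 3,4-dichlorophenyl at this place. Compound 1 has only a limit, so the step from it gives a floor on the size and not the size itself: the limit of > 100000 nM in this assay, at which 1 of the 4 values shown sits.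

The compounds shown leave open how a phenyl ring carrying a single fluorine, or one carrying an amine or a carboxylic acid, would read at this place. As far as these compounds go, all of them share the core of compound 1, so whether these steps hold on another core is also open.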